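Swapping Methyl for Chloro in an Antiproliferative Series

The source may report more compounds than this note shows. Statements on the series, on what has been measured and on what is new or still open speak of the compounds shown alone.

In a functional assay on CCRF-CEM cells (Homo sapiens) for antiproliferative activity, read by trypan blue exclusion, with a stated time of 72 h (on this read-out lower numbers stand for stronger inhibition and higher numbers for weaker inhibition), compound 1 `C[C@@H](Br)C(=O)Nc1cccc(C(=O)NC(N)=O)c1` gives 1470 nM as a measured number. Compound 2 `Cc1ccc(NC(=O)C(C)Br)cc1C(=O)NC(N)=O` gives only a limit of the assay, > 20000 nM in this case, and no exact number. Compound 3 `CC(Br)C(=O)Nc1ccc(Cl)c(C(=O)NC(N)=O)c1` carries chloro in place of methyl on an aromatic carbon and awaits measurement. For the measured compounds named here, no measured step shows what this swap does, so the only guide is compound 1 at 1470 nM and stronger inhibition is expected. The expected step of an at least 4.0-fold lower number from compound 2 to compound 3 (0.60 log units; beyond the scatter) is clearly beyond the usual scatter. For compound 3 the estimated value is 5000 nM with an expected range from 1000 nM to 20000 nM in repeated measurements.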

Compound 3, half-maximal inhibitory concentration: 2550 nM
Estimate against measurement, compound 3: 2.0-fold (0.29 log units) above; measured number inside the range.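

At this position, on the aromatic carbon ortho to the carbamoylcarbamoyl group, a single atom decides much in this assay: chloro in place of methyl gives an at least 7.8-fold lower number from compound 2 to compound 3 (0.89 log units; beyond the scatter). For the compounds shown here, this is the first measured step, and it shows that the group here strongly shapes the read-out. Its size is only a minimum, because compound 2 stands at a limit of the assay: the limit of > 20000 nM in this assay, at which 1 of the 3 values shown sits.

Going by these compounds, whether other groups at this position, such as fluoro, methoxy or a nitrile, behave like chloro or like methyl stays open. The reason for the step also stays open.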